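Ethyl to Isopropyl: A Small Branch on the Chain

A few compounds are considered here, and "the series" means these few. Any claim that something is new, unique, unknown or untested is made for them only; others in the source may bear on it.

In a functional assay on PC-3 cells (Homo sapiens) for cytotoxicity, read by WST assay, with a stated time of 3 days (on this read-out lower numbers stand for stronger inhibition and higher numbers for weaker inhibition), compound 1 (`CCn1ccnc1/C=C/C(=O)/C=C/c1coc2ccccc2c1=O`) gives 1800 nM. Its one measured relative, compound 2 (`CCCCCn1ccnc1/C=C/C(=O)/C=C/c1coc2ccccc2c1=O`), gives 2100 nM, so the two numbers sit within the scatter of each other. Compound 3 (`CC(C)n1ccnc1/C=C/C(=O)/C=C/c1coc2ccccc2c1=O`) has not been measured yet. It keeps the core of compound 1 and differs in one place: methyl in place of hydrogen on a saturated chain carbon bound to an aromatic nitrogen and a saturated chain carbon. Put simply, ethyl becomes isopropyl. Among the compounds with values here, the one measured step that bears on this is a 1.2-fold higher number from compound 1 to compound 2 (0.07 log units; within the scatter). That step adds a larger group than methyl, but at a different chain carbon, so it is only a loose guide. Even so, it stays within the scatter, and no step beyond the scatter is expected in this assay. The expected change is a 1.1-fold higher number from compound 1 to compound 3 (0.02 log units; within the scatter). For compound 3 the estimated value is 1900 nM, with an expected range of 900 nM to 4000 nM.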

Compound 3, half-maximal inhibitory concentration: 2300 nM
For compound 3 the middle estimate is 1.2-fold (0.08 log units) below the measured one; low and high end bracket the measured number.
By their numbers in this assay, from the lowest: compounds 1, 2 and 3 (each within the scatter of the next).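

In this assay the branch added at the saturated chain carbon bound to an aromatic nitrogen gives the first step measured at this carbon itself (a 1.3-fold higher number from compound 1 to compound 3 (0.11 log units; within the scatter)), and that step lies within the scatter. Putting isopropyl in place of pentyl on the aromatic nitrogen (a 1.1-fold higher number from compound 2 to compound 3 (0.04 log units; within the scatter)) also stays within the scatter, so ethyl, pentyl and isopropyl cannot be told apart on this read-out, whether the group is short, long or branched. No measured evidence is available to explain this result.

As far as these compounds go, whether a ring on that nitrogen, such as phenyl, or a chain ending in an amine or a carboxylic acid would take the number beyond the scatter remains open. All three compounds share the same core, so the effect of changes elsewhere in the molecule is also unknown.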